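Solubility notes: furanylmethyl to hydroxymethoxybenzyl on the cyclohexylmethyl core

The compounds below may be only part of what the source reports. "The series", "measured", "known", "first", "only" and "open" are said of these compounds alone.

Of the compounds shown here, two have been measured in a physicochemical assay for solubility, with a stated time of 18 h, at pH 7.4; on this read-out higher numbers stand for higher solubility and lower numbers for lower solubility. Compound 1 `COc1cccc(CNCCCNc2ccnc3cc(-c4ccc(F)cc4)ccc23)c1O` gives 32000 nM in this assay. Compound 2 `c1coc(CNCCCNc2ccnc3cc(CC4CCCCC4)ccc23)c1` gives 4200 nM in this assay and stands lowest of the two numbers; the two values differ beyond the usual scatter, but the compounds differ in more than one place, so the two values can only be set side by side.

Compound 3 `COc1cccc(CNCCCNc2ccnc3cc(CC4CCCCC4)ccc23)c1O` has not yet been measured. It carries the core of compound 2 and differs from it in one place: 2-hydroxy-3-methoxyphenyl in place of furan-2-yl on a saturated chain carbon bound to an amine nitrogen. Among the compounds with values here, this is the same side-chain end that compound 1 carries, on a different core, so the change has no direct single-point precedent here.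

For compound 3 in this assay, the expected direction is upward, because compound 1 with the same chain end gives 32000 nM, while the core difference remains unaccounted for. The step from compound 2 to compound 3 is estimated as a 2.1-fold higher number from compound 2 to compound 3 (0.33 log units; beyond the scatter), beyond the scatter but short of the number of compound 1. The estimate for compound 3 is 9000 nM, within a range of 3000 nM to 27000 nM.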

Compound 3, solubility: 4200 nM
Compound 3: middle estimate off by 2.1-fold (0.33 log units), on the high side; measured number inside the range.
By their numbers in this assay, from the lowest: compounds 2 and 3 (each within the scatter of the next); then compound 1.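

In this assay, 2-hydroxy-3-methoxyphenyl in place of furan-2-yl on a saturated chain carbon bound to an amine nitrogen reads as no change at the digits printed from compound 2 to compound 3 (within the scatter), so on the core of compound 2 this exchange does not separate the two compounds. Within the data shown here, with that chain end held constant, cyclohexylmethyl in place of 4-fluorophenyl on an aromatic carbon gives a 7.6-fold lower number from compound 1 to compound 3 (0.88 log units; beyond the scatter), which turns the earlier side-by-side gap into a single-point comparison and makes this the only step beyond the scatter among the three compounds. Nothing available here accounts for the size of either step.

Going by these compounds, it remains open whether furan-2-yl on the core of compound 1 would also leave the number within the scatter, and so whether the silence of the chain-end exchange holds on more than one core. Also open, on these data alone, is how a carboxylic acid or a morpholine at the chain end, or a simple methyl in place of cyclohexylmethyl on the aromatic carbon, would read on this scale.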